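The source may hold more compounds than are shown below. What is called first, only, known or untested is meant among the compounds shown, and "the series" means these compounds.

In an ADME assay on MT4 cells (Homo sapiens) for cytotoxicity, read by MTT assay (a lower number here means that less compound is tolerated, a higher number that more compound is tolerated), three compounds built on one shared core have been measured. Compound 1 `S=C(Nc1ccccc1)OCCc1ccccn1` carries no substituent on its aromatic ring; in this assay compound 1 reaches only > 100000 nM, which is a limit of the measurement and not a number. Compound 2 `CCc1ccc(NC(=S)OCCc2ccccn2)cc1` gives 44000 nM in this assay, and compound 3 `S=C(Nc1ccc(I)cc1)OCCc1ccccn1` gives 34000 nM. Compound 3 thus stands close to compound 2 among the numbers shown, the gap between them being a 1.3-fold lower number from compound 2 to compound 3 (0.11 log units; within the scatter), so the two cannot be told apart. Against the parent the step is an at least 2.9-fold lower number from compound 1 to compound 3 (0.46 log units; beyond the scatter), and for compound 2 it is an at least 2.2-fold lower number from compound 1 to compound 2 (0.35 log units; beyond the scatter); the size of both steps is bounded by the limit of > 100000 nM in this assay, at which 1 of the 3 values shown sits.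

Compound 4 `O=[N+]([O-])c1ccc(NC(=S)OCCc2ccccn2)cc1` is the next step: nitro in place of iodo on an aromatic carbon. The change takes away the iodo that carried the step of an at least 2.9-fold lower number from compound 1 to compound 3 (0.46 log units; beyond the scatter) and the small difference a 1.3-fold lower number from compound 2 to compound 3 (0.11 log units; within the scatter), and puts a nitro in its place. No measured compound carries a nitro, so nothing shown tells how far a nitro moves this assay. Ethyl and iodo on that aromatic carbon gave numbers of the same size, so the expected step for compound 4 is a 1.2-fold higher number from compound 3 to compound 4 (0.07 log units; within the scatter), not beyond the scatter. Compound 4 is therefore estimated at 40000 nM, within a range from 15000 nM to 100000 nM.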

Compound 4, half-maximal cytotoxic concentration: > 100000 nM
Compound 4: a limit, no number (the forecaster's own chance of this, stated with the estimate: 20%); at least 2.5-fold (0.39 log units) between middle value and limit.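

In this assay compound 4 gives > 100000 nM, which is a limit and not a number. Ethyl and iodo on this aromatic carbon, para to a large group, had left numbers that could not be told apart, so the earlier compounds gave no sign that the choice of group there mattered; the nitro shows that it can, with an at least 2.9-fold higher number from compound 3 to compound 4 (0.46 log units; beyond the scatter) and with an at least 2.2-fold higher number from compound 2 to compound 4 (0.35 log units; beyond the scatter) alongside it. The step from compound 1 to compound 4 cannot be read, because both of its ends are limits: the limit of > 100000 nM in this assay, at which 2 of the 4 values shown sit.

From the compounds shown here alone, whether the nitro on this carbon differs at all from the hydrogen of compound 1 therefore stays open, and so does the full size of the steps to compound 4, which are known only from one side. How an amine, a carboxylic acid or a longer alkyl chain on this aromatic carbon would stand in this assay is also open, and with only ethyl, iodo and nitro shown, no rule for the position can be drawn.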